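The source may hold more compounds than are shown below. What is called first, only, known or untested is meant among the compounds shown, and "the series" means these compounds.

Working notes on a set of four compounds built on a shared core, assayed in a functional assay on THP-1 cells (Homo sapiens) for cytotoxicity, read by MTT assay, with a stated time of 24 h; on this read-out higher numbers stand for weaker inhibition and lower numbers for stronger inhibition.

Compound 1 `COc1cc(/C=C2\CN(C)C/C(=C\c3ccc(Br)cc3)C2=O)cc(OC)c1` serves as the reference; in this assay compound 1 gives 4270 nM. Compound 2 `COc1cc(/C=C2\CN(C)C/C(=C\c3ccc(Cl)cc3Cl)C2=O)cc(OC)c1` carries one change against compound 1, namely (2,4-dichlorophenyl in place of 4-bromophenyl on a double-bonded chain carbon bound to a double-bonded ring carbon). The result in this assay is a 1.4-fold higher number from compound 1 to compound 2 (0.15 log units; within the scatter), so compound 2 gives 6070 nM, a number that is not separable from that of compound 1.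

Compound 3 `COc1cc(/C=C2\CN(C)C/C(=C\c3ccc(Br)cc3)C2=O)cc(OC)c1OC` stands on a different core. The difference between the two cores is methoxy in place of hydrogen on an aromatic carbon. In this assay compound 3 gives 5330 nM, and the step is a 1.2-fold higher number from compound 1 to compound 3 (0.10 log units; within the scatter). The values of compound 2 and compound 3 also lie within the scatter of each other, so no order among the three measured compounds can be read from these numbers.

Compound 4 `COc1cc(/C=C2\CN(C)C/C(=C\c3ccc(Cl)cc3Cl)C2=O)cc(OC)c1OC` is the not yet measured member. Against compound 3 it carries 2,4-dichlorophenyl in place of 4-bromophenyl on a double-bonded chain carbon bound to a double-bonded ring carbon, which is the same change as the one from compound 1 to compound 2, made here on the core of compound 3; the place of the change is described in the same words in both pairs. For the measured compounds named here, the only precedent for this change is the step from compound 1 to compound 2, which lay within the scatter, so compound 4 is expected to give a number close to that of compound 3, with the estimated step being a 1.3-fold higher number from compound 3 to compound 4 (0.12 log units; within the scatter). Going by the values given here, this expectation rests on the single measured step, a thin basis. On that basis compound 4 is estimated at 7000 nM, with the expected range running from 3500 nM to 14000 nM.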

Compound 4, half-maximal inhibitory concentration: 5020 nM
Compound 4: middle estimate off by 1.4-fold (0.14 log units), on the high side; the range from low to high includes it.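

In this assay, 2,4-dichlorophenyl in place of 4-bromophenyl on the core of compound 3 gives a 1.1-fold lower number from compound 3 to compound 4 (0.03 log units; within the scatter), and this step does not differ from the one on the core of compound 1: the same change on two cores in this assay, a 1.4-fold higher number (0.15 log units; within the scatter) from compound 1 to compound 2 and a 1.1-fold lower number (0.03 log units; within the scatter) from compound 3 to compound 4, 1.5-fold (0.18 log units) apart, within the scatter of two such steps. Read the other way round, methoxy in place of hydrogen on an aromatic carbon gives a 1.2-fold lower number from compound 2 to compound 4 (0.08 log units; within the scatter), and again the two cores do not differ: the same change on two cores in this assay, a 1.2-fold higher number (0.10 log units; within the scatter) from compound 1 to compound 3 and a 1.2-fold lower number (0.08 log units; within the scatter) from compound 2 to compound 4, 1.5-fold (0.18 log units) apart, within the scatter of two such steps. For the compounds shown here, this shows that neither change moves the number beyond the scatter on either core, so nothing here points to a dependence on the core; it does not show that either change carries a real effect from one core to the other, since no step in this set can be separated from the scatter and a transfer of a measurable effect cannot be tested.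

From the compounds shown here alone, the aryl groups seen here are only 4-bromophenyl and 2,4-dichlorophenyl, so it stays open whether an amine or a carboxylic acid on that phenyl ring, on a double-bonded chain carbon bound to a double-bonded ring carbon, would give a step beyond the scatter. Also open, going by these compounds, is whether a longer chain in place of the methoxy groups would shift the number in this assay.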